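A propargyl swap at the limit of a cytotoxicity assay

The source may report more compounds than this note shows. Statements on the series, on what has been measured and on what is new or still open speak of the compounds shown alone.

Measured in an ADME assay on L02 cells (Homo sapiens) for cytotoxicity, read by MTT assay; a lower number here means a stronger inhibitor, a higher number a weaker inhibitor:
- Compound 1 `COc1ccc(/C=C/C(=O)c2ccc(OC)c3c2OC(C)(C)C=C3)cc1O` gives > 10000 nM (a limit)
- Compound 2 `COc1ccc(/C=C/C(=O)c2ccc(OC)c3c2OC(C)(C)C=C3)cc1OCC=C(C)C` gives > 10000 nM (a limit)

Compound 2 stands at > 10000 nM, which is a limit of the assay and not a number. Compound 3 `C#CCOc1cc(/C=C/C(=O)c2ccc(OC)c3c2OC(C)(C)C=C3)ccc1OC` keeps the shared core and changes one group of compound 2: ethynyl in place of 2-methylprop-1-en-1-yl on a saturated chain carbon bound to an oxygen on an aromatic ring. In words, ethynyl takes the place of 2-methylprop-1-en-1-yl on a saturated chain carbon bound to an oxygen on an aromatic ring, so 3-methylbut-2-en-1-yl becomes propargyl.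

For the measured compounds named here, only one measured step bears on this change: a step that the two limits leave unreadable from compound 1 to compound 2. Its size cannot be read, so it offers no guide to size or direction. Going by the values given here, the only firm evidence is the limit of > 10000 nM in this assay, at which 2 of the 2 values shown sit. No readable step is therefore expected in this assay, and compound 3 is expected to stay near that limit, given the shared position of compound 1 and compound 2 at the limit of > 10000 nM in this assay, at which 2 of the 2 values shown sit. The estimated change is a step that the limit leaves unreadable from compound 2 to compound 3. For compound 3 the estimated value is 20000 nM, with an expected range from 8000 nM to 50000 nM.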

Compound 3, half-maximal inhibitory concentration: > 10000 nM
Compound 3: a limit, no number; the forecaster's own chance of this, stated with the estimate: 85%; the middle value lies beyond the limit too.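

In this assay compound 3 gives > 10000 nM, which is a limit of the assay and not a number. The steps among compound 1, compound 2 and compound 3 therefore cannot be read: the limit of > 10000 nM in this assay, at which 3 of the 3 values shown sit. Still open is whether propargyl in place of 3-methylbut-2-en-1-yl changes anything in this assay, since none of these compounds gives an actual number.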